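A few compounds are considered here, and "the series" means these few. Any claim that something is new, unique, unknown or untested is made for them only; others in the source may bear on it.

Measured compounds:
compound 1, `Cc1ccccc1Nc1nc(NCc2ccccc2)ncc1Cl` — > 100000 nM
compound 2, `Cc1ccc(CNc2nc(Nc3ccc(N4CCN(C)CC4)cn3)ncc2Cl)cc1` — 18600 nM

Of the compounds shown here, two have been tested in a functional assay on MDA-MB-231 cells (Homo sapiens) for inhibition, read by CCK-8 assay, with a stated time of 48 h; a lower number here means a stronger inhibitor of growth, a higher number a weaker inhibitor of growth. Compound 1, `Cc1ccccc1Nc1nc(NCc2ccccc2)ncc1Cl`, gives only a limit in this assay, > 100000 nM, which marks the limit of > 100000 nM in this assay, at which 1 of the 2 values shown sits, rather than a measured number. For the measured compounds named here, compound 2, `Cc1ccc(CNc2nc(Nc3ccc(N4CCN(C)CC4)cn3)ncc2Cl)cc1`, is the only compound with a real number in this assay, 18600 nM, so it stands alone as the one point of reference; the two structures differ in several places at once, so their values cannot be compared as a single step.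

Compound 3, `CC(C)c1cccc(Nc2nc(Nc3ccc(N4CCN(C)CC4)cn3)ncc2Cl)c1`, has not yet been measured. It differs from compound 2 in one place: 3-isopropylphenyl in place of 4-methylbenzyl on a nitrogen on an aromatic ring. The group that leaves and the group that enters both carry one six-membered aromatic ring of carbon only, and neither adds a hydrogen-bond donor or acceptor. Going by the values given here, with no measured step of this kind to lean on, the expectation is a modest change in this assay, within or near the usual scatter. The step of a 2.1-fold lower number from compound 2 to compound 3 (0.32 log units; beyond the scatter) is my estimate. Compound 3 is therefore expected to give about 9000 nM in this assay, between 2500 nM and 40000 nM.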

Compound 3, concentration for 50% growth inhibition: 5590 nM
For compound 3 the middle estimate is 1.6-fold (0.21 log units) above the measured one; low and high end bracket the measured number.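

For the compounds shown here, this is the first step in this assay that can be read as one change: 3-isopropylphenyl in place of 4-methylbenzyl on a nitrogen on an aromatic ring gives a 3.3-fold lower number from compound 2 to compound 3 (0.52 log units; beyond the scatter). The number therefore responds to what this nitrogen carries, even though the leaving and entering groups each hold one six-membered aromatic ring of carbon only and neither has a hydrogen-bond donor or acceptor, so those counts alone do not settle the value. Nothing measured here accounts for the size of this step.

The change alters two features at once, the benzyl carbon that links the ring to the nitrogen and the alkyl group on the ring, so the compounds shown leave open which of the two carries the step. They also leave open how this position would respond to a ring bearing a different kind of group, such as an amine or a carboxylic acid, in place of the methyl or isopropyl group.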